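Salicylanilide Cytotoxicity: Removing a Chloro Group

This account rests on a few compounds, and the source may have more. Where it says the series, first, only, none or still open, it means among the compounds named here.

Measured compounds:
compound 1, `O=C(Nc1ccc([N+](=O)[O-])c(Cl)c1)c1cc(Cl)ccc1O`: 15100 nM
compound 2, `O=C(Nc1ccc([N+](=O)[O-])cc1)c1cc(Cl)ccc1O`: 27100 nM
compound 3, `O=C(NCc1ccc(Cl)cc1Cl)c1cc(Cl)ccc1O`: 30900 nM

In an ADME assay on A549 cells (Homo sapiens) for cytotoxicity, read by resazurin assay, with a stated time of 48 h (on this read-out higher numbers stand for lower toxicity in this test and lower numbers for higher toxicity in this test), compound 1 gives 15100 nM, compound 2 gives 27100 nM and compound 3 gives 30900 nM. Compound 3 has the highest number of the three, yet its gap to compound 2 is within the scatter, so no order between those two can be claimed; only its gap to compound 1 lies beyond the scatter.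

Compound 1 and compound 2 differ by one change, (hydrogen in place of chloro on an aromatic carbon). That step is a 1.8-fold higher number from compound 1 to compound 2 (0.25 log units; within the scatter). Compound 3 carries a different core, and the difference between the core of compound 3 and the core of compound 1 is not broken down here.

The not yet measured compound 4, `O=C(NCc1ccc(Cl)cc1)c1cc(Cl)ccc1O`, is derived from compound 3 by hydrogen in place of chloro on an aromatic carbon. Among the compounds with values here, this is the same kind of change as the one from compound 1 to compound 2, but not the same: there the leaving chloro stood ortho to a nitro group and meta to a large group, here it stands ortho to a large group and meta to a chloro group.

For compound 4 in this assay the expected step is a 1.3-fold higher number from compound 3 to compound 4 (0.11 log units; within the scatter), a small move of the same direction as the earlier one, resting on compound 1 and compound 2 because a 1.8-fold higher number from compound 1 to compound 2 (0.25 log units; within the scatter) stayed within the scatter. Compound 4 is therefore estimated at 40000 nM, within the range 18000 nM to 90000 nM.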

Compound 4, half-maximal cytotoxic concentration: 27100 nM
The estimate for compound 4 lay 1.5-fold (0.17 log units) above the measured number; the range from low to high includes it.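

Removing the chloro group that stands ortho to a large group and meta to a chloro group gives, in this assay, a 1.1-fold lower number from compound 3 to compound 4 (0.06 log units; within the scatter). Set beside the earlier step on the other core, this step cannot be told apart from it: the same change on two cores in this assay, a 1.8-fold higher number (0.25 log units; within the scatter) from compound 1 to compound 2 and a 1.1-fold lower number (0.06 log units; within the scatter) from compound 3 to compound 4, 2.0-fold (0.31 log units) apart, within the scatter of two such steps. This shows that, in this test, the change gave no step beyond the scatter on either core and no measurable difference between the two cores, but it does not show that the chloro group has no effect or that the change acts alike on both, as two steps this small could hide a real difference in either direction, and the chloro group leaves a different place in each pair.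

The compounds shown leave open whether a group other than chloro at these places, such as a methyl, a methoxy or a carboxylic acid, would give a step beyond the scatter on either core. They also leave open whether the result would hold with a longer chain between the amide nitrogen and the chlorinated ring, or with an amine on that ring.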